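The source may hold more compounds than are shown below. What is called first, only, known or untested is meant among the compounds shown, and "the series" means these compounds.

Compound 1, `CC(=O)n1c(=S)[nH]c2ccccc21`, is the starting point of this comparison. For the measured compounds named here, in a physicochemical assay for solubility (a lower number here means a less soluble compound, a higher number a more soluble compound), compound 1 gives 460000 nM, the highest of the three numbers measured so far. Its nearest neighbour is compound 2, `CCC(=O)n1c(=S)[nH]c2ccccc21`, which in this assay gives 180000 nM; the furthest is compound 3, `CCCCCC(=O)n1c(=S)oc2ccccc21`, which gives 130000 nM in this assay. Compound 1 and compound 3 share no single-point relationship, so only their two values can be compared.

The unmeasured compound 4, `CCn1c(=S)n(C(C)=O)c2ccccc21`, differs from compound 1 in one place: ethyl in place of hydrogen on an aromatic nitrogen. Going by the values given here, the only measured step that resembles this change in spirit is the growth of a small carbon group in the chain, a 2.6-fold lower number from compound 1 to compound 2 (0.41 log units; beyond the scatter), a modest drop that is nonetheless beyond the scatter. Compound 4 carries more carbon than compound 1 in a place where compound 1 has only hydrogen, so a drop of similar or somewhat larger size in this assay is expected, in the downward direction, because the step of a 2.6-fold lower number from compound 1 to compound 2 (0.41 log units; beyond the scatter) already went that way for a smaller addition.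

Compound 4 is therefore expected to give 100000 nM in this assay, within a range of 40000 nM to 250000 nM, which would mean a step of a 4.6-fold lower number from compound 1 to compound 4 (0.66 log units; beyond the scatter).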

Compound 4, solubility: 380000 nM
For compound 4 the middle estimate is 3.8-fold (0.58 log units) below the measured one; measured number outside the range, above it.
By their numbers in this assay, from the lowest: compounds 3 and 2 (each within the scatter of the next); then compounds 4 and 1 (each within the scatter of the next).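

In this assay, ethyl in place of hydrogen on an aromatic nitrogen gives a 1.2-fold lower number from compound 1 to compound 4 (0.08 log units; within the scatter) and so leaves no change that can be told from ordinary repeat-to-repeat variation. This position of the core of compound 1 therefore accepts this group, with its added carbon atoms, without a readable shift in the number. For the compounds shown here, the only earlier single-place step, a 2.6-fold lower number from compound 1 to compound 2 (0.41 log units; beyond the scatter), put methyl in place of hydrogen on a saturated chain carbon bound to a carbonyl carbon and lay beyond the scatter, so across these two steps added carbon does not have the same outcome in both places, and no measurement here explains the difference.

Going by these compounds, whether the aromatic nitrogen stays as undemanding with other groups remains open, since a longer chain, a carboxylic acid or an amine in place of the ethyl could give a number clearly apart from that of compound 1. A single substituent at this position also cannot show whether ethyl would behave the same way on a core carrying a different chain on its carbonyl carbon.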